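A few compounds are considered here, and "the series" means these few. Any claim that something is new, unique, unknown or untested is made for them only; others in the source may bear on it.

Measured so far in a functional assay on SW480 cells (Homo sapiens) for cytotoxicity, read by MTT assay, with a stated time of 4 days; a higher number here means a weaker inhibitor, a lower number a stronger inhibitor:

compound 1 `Cc1ccc(-c2cn(C[C@H]3c4c(ccc(OS(=O)(=O)c5ccc(C)cc5)c4C)[C@@H]4CC[C@@]5(C)C[C@]43CC5=O)nn2)cc1` gives > 20000 nM
compound 2 `C=C1C[C@]23C[C@@]1(O)CC[C@@H]2c1cccc(C)c1[C@@H]3Cn1cc(-c2ccc(C(F)(F)F)cc2)nn1` gives > 20000 nM
compound 3 `Cc1ccc(S(=O)(=O)Oc2ccc3c(c2C)[C@H](Cn2cc(-c4ccc(C(F)(F)F)cc4)nn2)[C@@]24CC(=O)[C@@](C)(CC[C@@H]32)C4)cc1` gives > 20000 nM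

Each of these three values is a limit of this assay, not a number. Among the compounds with values here, the one change that can be followed between measured compounds is the one from compound 3 to compound 1, (methyl in place of trifluoromethyl on an aromatic carbon), and the step it made is a step that the two limits leave unreadable from compound 3 to compound 1; the step cannot be read because both ends sit at the limit of > 20000 nM in this assay, at which 3 of the 3 values shown sit.

Compound 4 `C=C1C[C@]23C[C@@]1(O)CC[C@@H]2c1cccc(C)c1[C@@H]3Cn1cc(-c2ccc(C)cc2)nn1` is not yet measured in this assay. It is made from compound 2 by methyl in place of trifluoromethyl on an aromatic carbon, the same change as from compound 3 to compound 1. The difference between the core of compound 2 and the core of compound 3 is not broken down here.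

For compound 4 in this assay the expectation is a step that the limit leaves unreadable from compound 2 to compound 4, which means no readable move. That expectation rests on compound 2 sitting at the limit > 20000 nM and on the same change from compound 3 to compound 1 leaving a step that is not readable, a step that the two limits leave unreadable from compound 3 to compound 1. Compound 4 is therefore expected to come out around 25000 nM, most likely again as a limit, with a range of 8000 nM to 80000 nM.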

Compound 4, half-maximal inhibitory concentration: > 20000 nM
Compound 4: only a limit was reported (the forecaster's own chance of this, stated with the estimate: 85%); the middle value lies beyond the limit too.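

In this assay compound 4 gives > 20000 nM, which is a limit and not a number. The step from compound 2 to compound 4 cannot be read, because both ends sit at a limit: the limit of > 20000 nM in this assay, at which 4 of the 4 values shown sit.

The compounds shown leave open whether methyl in place of trifluoromethyl moves the value at all on either core, as no compound here has a value that can be read as a number.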